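The source may report more compounds than this note shows. Statements on the series, on what has been measured and on what is new or still open speak of the compounds shown alone.

Measured so far in an assay for inhibition of alcohol dehydrogenase (Equus caballus); on this read-out higher numbers stand for weaker inhibition and lower numbers for stronger inhibition:
compound 1 `NC(=O)CCCCO`: 4400000 nM
compound 2 `NC(=O)CCCO`: 6800000 nM

For the measured compounds named here, compound 2 stands highest of the two numbers; the single measured step, a 1.5-fold higher number from compound 1 to compound 2 (0.19 log units; within the scatter), is within the scatter, so the two compounds cannot be ordered on this read-out.

Compound 3 `NC(=O)CCCCCO` is not yet measured. Against compound 2 the change is 2-hydroxyethyl in place of hydroxy on a saturated chain carbon, three bonds along the chain from a carbonyl carbon. Going by the values given here, the only measured step that bears on it is a 1.5-fold higher number from compound 1 to compound 2 (0.19 log units; within the scatter), which runs the other way, shortening the chain by one carbon, and stayed within the scatter. Because a 1.5-fold higher number from compound 1 to compound 2 (0.19 log units; within the scatter) is within the scatter, no step beyond the scatter is expected from compound 2 to compound 3, with at most a small lowering of the number. The step to compound 3 is expected to be a 1.9-fold lower number from compound 2 to compound 3 (0.29 log units; within the scatter). Compound 3 is estimated at 3500000 nM in this assay, with a range from 1200000 nM to 10000000 nM.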

Compound 3, inhibition constant: 1500000 nM
The estimate for compound 3 lay 2.3-fold (0.37 log units) above the measured number; measured number inside the range.
By their numbers in this assay, from the lowest: compound 3; then compounds 1 and 2 (each within the scatter of the next).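

In this assay, 2-hydroxyethyl in place of hydroxy on a saturated chain carbon, three bonds along the chain from a carbonyl carbon, gives a 4.5-fold lower number from compound 2 to compound 3 (0.66 log units; beyond the scatter), so this position does respond to a change in the chain, which a 1.5-fold higher number from compound 1 to compound 2 (0.19 log units; within the scatter) could not show. Hydroxymethyl in place of hydroxy on a saturated chain carbon, four bonds along the chain from a carbonyl carbon, gives a 2.9-fold lower number from compound 1 to compound 3 (0.47 log units; beyond the scatter), so compound 3 stands apart from both shorter compounds, although those two cannot be ordered against each other. No supporting data bear on the reason for this lowering.

Going by these compounds, whether a longer chain would lower the number further or reverse the trend remains open. Also open, on these data alone, is whether the series would keep this behaviour with an amine or a carboxylic acid in place of the hydroxy.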